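The source may hold more compounds than are shown below. What is called first, only, known or untested is meant among the compounds shown, and "the series" means these compounds.

Series notes. Compound 3 `CN(C)c1ccc(/C=C(/SCc2ccc(Cl)c(Cl)c2)C(=O)c2ccc(Cl)cc2)cc1` and compound 1 `Cc1ccsc1/C=C(/SCc1ccc(Cl)c(Cl)c1)C(=O)c1ccc(Cl)cc1` share one core and differ only by the change (3-methylthiophen-2-yl in place of 4-(dimethylamino)phenyl on a double-bonded chain carbon bound to a double-bonded chain carbon). In a functional assay on DU-145 cells (Homo sapiens) for inhibition, read by trypan blue exclusion, with a stated time of 96 h (on this read-out higher numbers stand for weaker inhibition of growth and lower numbers for stronger inhibition of growth), compound 3 gives 50000 nM, and in this assay compound 1 gives 50000 nM; the measured step is no change at the digits printed from compound 3 to compound 1 (within the scatter).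

Compound 2 `CN(C)c1ccc(/C=C(/SCc2ccc(Cl)cc2)C(=O)c2ccc([N+](=O)[O-])cc2)cc1` carries a different core from compound 3, and the difference between the two cores is not broken down here. In this assay compound 2 gives only a limit, > 100000 nM, namely (the limit of > 100000 nM in this assay, at which 1 of the 3 values shown sits).

Compound 4 `Cc1ccsc1/C=C(/SCc1ccc(Cl)cc1)C(=O)c1ccc([N+](=O)[O-])cc1` is not yet measured and stands to compound 2 as compound 1 stands to compound 3: the change (3-methylthiophen-2-yl in place of 4-(dimethylamino)phenyl on a double-bonded chain carbon bound to a double-bonded chain carbon). The place is described in the same words for both pairs, so this is the same kind of change made on another core. Because the step of no change at the digits printed from compound 3 to compound 1 (within the scatter) stayed within the scatter, the step of a number no higher from compound 2 to compound 4 (the limit leaves the size open) is expected. Compound 4 is therefore expected to give about 100000 nM in this assay, within 50000 nM to 200000 nM, with a real chance that again only a limit is reported.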

Compound 4, concentration for 50% growth inhibition: > 100000 nM
Compound 4: only a limit was reported; the forecaster's own chance of this, stated with the estimate: 60%; the middle value lies on the limit itself.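

In this assay, compound 2 and compound 4 both give only a limit, so no step between them can be read: the limit of > 100000 nM in this assay, at which 2 of the 4 values shown sit.

The compounds shown leave open whether 3-methylthiophen-2-yl in place of 4-(dimethylamino)phenyl changes growth inhibition on the core of compound 2.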